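Benzyloxy in Place of 4-Chlorophenyl on a Shared Core

The source may report more compounds than this note shows. Statements on the series, on what has been measured and on what is new or still open speak of the compounds shown alone.

Measured compounds:
compound 1 `CCc1cc(Br)c(S(C)(=O)=O)cc1C(=O)N=C(N)N` — 41 nM
compound 2 `Cc1c(C(=O)N=C(N)N)cc(S(C)(=O)=O)c(Cl)c1[N+](=O)[O-]` — 44 nM
compound 3 `Cc1cc(-c2ccc(Cl)cc2)c(S(C)(=O)=O)cc1C(=O)N=C(N)N` — 45 nM

In a functional assay for inhibition of sodium/hydrogen exchanger (Oryctolagus cuniculus) (on this read-out lower numbers stand for stronger inhibition and higher numbers for weaker inhibition), compound 3 gives 45 nM, the highest of the three numbers, yet its gaps to compound 2 and compound 1 both lie within the scatter, so the three compounds cannot be told apart on potency. Compound 4 `Cc1cc(OCc2ccccc2)c(S(C)(=O)=O)cc1C(=O)N=C(N)N` is the untested partner: benzyloxy in place of 4-chlorophenyl on an aromatic carbon. Among the measured set, quite different groups at this position leave the number almost unchanged, which gives no sign of a large shift in either direction. The step from compound 3 to compound 4 is therefore expected to be small, a 1.2-fold higher number from compound 3 to compound 4 (0.09 log units; within the scatter), not beyond the scatter. Compound 4 is estimated at 55 nM, within 20 nM to 160 nM.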

Compound 4, half-maximal inhibitory concentration: 28 nM
Compound 4: the middle estimate sits 2.0-fold (0.29 log units) above what was measured; measured number inside the range.
By their numbers in this assay, from the lowest: compounds 4, 1, 2 and 3 (each within the scatter of the next).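

Within the data shown here, putting benzyloxy in place of 4-chlorophenyl on this aromatic carbon gives a 1.6-fold lower number from compound 3 to compound 4 (0.21 log units; within the scatter) in this assay, the one direct comparison at this position, and the two compounds cannot be told apart. So a change that adds a hydrogen-bond acceptor while keeping a six-membered aromatic ring of carbon only leaves the number within the scatter. Nothing measured here ties this result to any property of either group. Still open, going by these compounds, is whether an amine or a carboxylic acid on this carbon would also stay within the scatter of compound 4.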